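Vinyl in place of phenoxy in the ethylsulfanyl compound

A few compounds are considered here, and "the series" means these few. Any claim that something is new, unique, unknown or untested is made for them only; others in the source may bear on it.

Measured so far in a functional assay on HT-29 cells (Homo sapiens) for inhibition, read by sulforhodamine B assay, with a stated time of 72 h; on this read-out lower numbers stand for stronger inhibition and higher numbers for weaker inhibition:
- compound 1 (`CCSc1ccc(C2C(Oc3ccccc3)C(=O)N2c2cc(OC)c(OC)c(OC)c2)cc1`) gives 632 nM
- compound 2 (`CCOc1ccc(C2C(C3CC3)C(=O)N2c2cc(OC)c(OC)c(OC)c2)cc1`) gives 63 nM

Compound 1 stands at the higher of the two numbers, and its gap to compound 2 lies beyond the scatter. Compound 3 (`C=CC1C(=O)N(c2cc(OC)c(OC)c(OC)c2)C1c1ccc(SCC)cc1`) is still unmeasured. It departs from compound 1 in one place (vinyl in place of phenoxy on a saturated ring carbon): vinyl in place of phenoxy on a saturated ring carbon, next to the ring atom that bears a 4-(ethylsulfanyl)phenyl group. Going by the values given here, no measured pair isolates this change. Compound 2 also lacks the phenoxy group and gives 63 nM, although it differs from compound 1 elsewhere too. On that weak evidence, a step to a lower number, beyond the scatter, is expected in this assay. The estimated move is a 7.9-fold lower number from compound 1 to compound 3 (0.90 log units; beyond the scatter) in size. Compound 3 is expected at 80 nM, with 20 nM to 320 nM as the estimated range.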

Compound 3, half-maximal inhibitory concentration: 257 nM
Beside the measured number, compound 3's estimate is 3.2-fold (0.51 log units) below it; the range from low to high includes it.
By their numbers in this assay, from the lowest: compound 2; then compound 3; then compound 1.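

In this assay, going by these compounds alone, vinyl in place of phenoxy on the saturated ring carbon gives a 2.5-fold lower number from compound 1 to compound 3 (0.39 log units; beyond the scatter) and is the only single-place change available in this set. The phenoxy group, with its six-membered aromatic ring and its oxygen, is therefore not required at this position for inhibition on this read-out, and a vinyl group with no ring gives a modestly lower number on the same ethylsulfanyl background. Nothing available on these compounds accounts for the step.

This single pair cannot separate the loss of the aromatic ring from the loss of the oxygen or from the entry of the double bond. It also leaves open how a propyl chain or a primary amine would behave on this ring carbon, and whether the vinyl step carries over when ethoxy replaces ethylsulfanyl.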